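Swapping the Amide Substituent of Compound 3

The source may report more compounds than this note shows. Statements on the series, on what has been measured and on what is new or still open speak of the compounds shown alone.

Three compounds have been measured in a functional assay on the whole organism with Mus musculus as the target; a higher number here means that more compound is needed for the effect, a lower number that less compound is needed:

Compound 1 `CN(C)C(=O)Cn1c(-c2ccc(Br)cc2)nc2cccnc21` gives 7 mg/kg
Compound 2 `CN(C)C(=O)Cn1c(-c2ccsc2)nc2cccnc21` gives 38 mg/kg
Compound 3 `O=C(Cn1c(-c2ccc(Cl)cc2)nc2cccnc21)Nc1ccccn1` gives 100 mg/kg

Compound 3 stands at the highest number of the three, above compound 2 and well above compound 1. The next compound, compound 4 `CN(C)CCCNC(=O)Cn1c(-c2ccc(Cl)cc2)nc2cccnc21`, differs from compound 3 in one place: 3-(dimethylamino)propyl in place of pyridin-2-yl on an amide-type nitrogen.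

Among the measured compounds shown here, the only measured step, a 5.4-fold higher number from compound 1 to compound 2 (0.73 log units; beyond the scatter), concerns the aromatic group attached to the shared core, not the amide, so it does not bear directly on this change. Compounds 1 and 2 both carry a dimethyl amide and compound 3 a pyridin-2-yl amide, but compound 3 also differs from compound 1 in its aromatic group, so the share of the amide in its high number cannot be separated. Compound 4 returns to a dimethylamino group, now on a 3-(dimethylamino)propyl chain, which gives a slight lean towards the lower numbers of compounds 1 and 2.

Compound 4 is therefore expected to show a modest fall, a 2.5-fold lower number from compound 3 to compound 4 (0.40 log units; beyond the scatter), with wide uncertainty. The estimate for compound 4 is 40 mg/kg, in a range from 10 mg/kg to 160 mg/kg.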

Compound 4, dose for half-maximal effect: 64 mg/kg
Beside the measured number, compound 4's estimate is 1.6-fold (0.20 log units) below it; the measured number falls inside the stated range.
By their numbers in this assay, from the lowest: compound 1; then compounds 2, 4 and 3 (each within the scatter of the next, the first and the last beyond it).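

Among the compounds shown here, this step is the first view of the amide-type nitrogen with the aromatic group held fixed: in this assay, 3-(dimethylamino)propyl in place of pyridin-2-yl gives a 1.6-fold lower number from compound 3 to compound 4 (0.19 log units; within the scatter) and so does not separate the two groups. An open chain with no ring and a six-membered aromatic ring, each with the same count of heavy atoms, therefore read alike at this place, so the aromatic ring is not required for a number of this size. Nothing available explains why these two groups read alike.

Going by these compounds, it remains open whether any group on this nitrogen can bring the number close to that of compound 1, 7 mg/kg. A phenyl ring, a morpholine at the end of the chain, or a simple methyl on the nitrogen would each test this.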